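The source may report more compounds than this note shows. Statements on the series, on what has been measured and on what is new or still open speak of the compounds shown alone.

Working notes on the series. Compound 1 `CCCCNc1ccnc2cc(F)ccc12` and compound 2 `CN(C)CCNc1ccnc2cc(Cl)ccc12` share one core and differ in the amine chain and in the halogen. In a functional assay on MCF7 cells (Homo sapiens) for cytotoxicity, read by sulforhodamine B assay, with a stated time of 48 h, in the presence of a further agent that is not named here (on this read-out higher numbers stand for weaker inhibition of growth and lower numbers for stronger inhibition of growth), compound 1 gives 5780 nM. In the same this assay compound 2 gives 4960 nM, a number that sits with that of compound 1 inside the usual scatter, so the two cannot be separated. Compound 3 `CN(C)CCNc1ccnc2cc(F)ccc12` is not yet measured; it differs from compound 2 by fluoro in place of chloro on an aromatic carbon. Within the data shown here, no step between measured compounds covers this change; no shift beyond the scatter is expected, the step from a 1.2-fold higher number from compound 2 to compound 3 (0.08 log units; within the scatter) being the estimate. Compound 3 is therefore expected near 6000 nM, within 2500 nM to 14000 nM.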

Compound 3, concentration for 50% growth inhibition: 2560 nM
Compound 3: middle estimate off by 2.3-fold (0.37 log units), on the high side, within the range that was stated.
By their numbers in this assay, from the lowest: compounds 3, 2 and 1 (each within the scatter of the next, the first and the last beyond it).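

In this assay, fluoro in place of chloro on this aromatic carbon gives a 1.9-fold lower number from compound 2 to compound 3 (0.29 log units; within the scatter), so the halogen change at this position cannot be separated from assay noise. With fluoro held fixed, dimethylamino in place of ethyl on the saturated chain carbon gives a 2.3-fold lower number from compound 1 to compound 3 (0.35 log units; beyond the scatter), a modest step and the only one here beyond the scatter. No evidence at hand bears on the cause of either step.

Still open, on these data alone, is whether bromo or methoxy on this aromatic carbon, or a diethylamino group or longer chain on the amine side, would give a step beyond the scatter.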